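Notes on the undecyloxy and benzyloxy series: step to compound 4

The source may hold more compounds than are shown below. What is called first, only, known or untested is meant among the compounds shown, and "the series" means these compounds.

compound 1, `CCCCCCCCCCCOc1ccccc1CCC(=O)OCCCOP(=O)(O)OC[C@H](N)C(=O)O`, gives 14.6% in an assay on cells for agonist activity at probable G-protein coupled receptor 34 (Mus musculus), with a stated time of 1 h; a lower number here means a smaller maximal response, a higher number a larger maximal response
compound 2, `N[C@@H](COP(=O)(O)OCCCOC(=O)CCc1ccccc1OCc1cccc(Oc2ccccc2)c1)C(=O)O`, gives 19.4% in this assay
compound 3, `N[C@@H](COP(=O)(O)OCCCOC(=O)CCc1ccccc1OCc1cccc(Cc2ccccc2)c1)C(=O)O`, gives 14.5% in this assay

Compound 3 carries the lowest of the three numbers, but its distance to compound 1 and its distance to compound 2 both lie within the scatter, so no order among the three can be read from this assay.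

Compound 4, `N[C@@H](COP(=O)(O)OCCCOC(=O)CCc1ccccc1OCc1cccc(OC2CCCCC2)c1)C(=O)O`, is the next member. It differs from compound 3 as follows: cyclohexyloxy in place of benzyl on an aromatic carbon. Among the measured compounds shown here, the one step already measured at this position is a number 4.9 percentage points lower from compound 2 to compound 3 (within the scatter), within the scatter. That step exchanged phenoxy for benzyl; the change to compound 4 instead exchanges benzyl for cyclohexyloxy, so the measured step bears on it only as a sign that the group on this aromatic carbon has so far not moved the maximal response in this assay beyond the scatter. Nothing measured speaks for a direction. The expectation for compound 4 is therefore a step of a number 1.5 percentage points higher from compound 3 to compound 4 (within the scatter), with no change beyond the scatter. Compound 4 is estimated at 16%, between 8% and 26%.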

Compound 4, largest response reached (Emax), in percent of the reference or control that the assay uses: 18.8%
Beside the measured number, compound 4's estimate is 2.8 percentage points below it; measured number inside the range.
By their numbers in this assay, from the lowest: compounds 3, 1, 4 and 2 (each within the scatter of the next).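

In this assay, cyclohexyloxy in place of benzyl on this aromatic carbon gives a number 4.3 percentage points higher from compound 3 to compound 4 (within the scatter), so a non-aromatic carbon ring joined through oxygen takes the place of an aromatic carbon ring joined through carbon with no readable change in maximal response. The series now also holds a pair with the oxygen kept in place, where cyclohexyl in place of phenyl gives a number 0.6 percentage points lower from compound 2 to compound 4 (within the scatter), and the loss of aromaticity in this ring therefore leaves no readable mark on the number. Nothing on hand bears on why these two exchanges leave the response within the scatter.

All groups shown at this place are large and end in a six-membered carbon ring, so it remains open whether an amine or a carboxylic acid here would move the maximal response in this assay beyond the scatter. Also open is what a longer chain in place of cyclohexyl on that oxygen would give, as the compounds shown contain no such pair.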